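Phenylsulfonyl in Place of Propyl: One Expected Step

The source may hold more compounds than are shown below. What is called first, only, known or untested is meant among the compounds shown, and "the series" means these compounds.

Compound 1 `Cc1cccnc1-c1ccc(C(=O)Nc2ccc(C(C)C)cc2)cc1`: 43 nM
Compound 2 `CCCNc1cccnc1-c1ccc(C(=O)Nc2ccc(C(C)(C)C)cc2)cc1`: 37 nM

In a functional assay for antagonist activity at transient receptor potential cation channel subfamily V member 1 (Rattus norvegicus) (a higher number here means a weaker inhibitor, a lower number a stronger inhibitor), compound 1 gives 43 nM and compound 2 gives 37 nM; the two numbers lie within the usual scatter of each other, so neither compound can be called the stronger inhibitor on this evidence. Compound 3 `CC(C)(C)c1ccc(NC(=O)c2ccc(-c3ncccc3NS(=O)(=O)c3ccccc3)cc2)cc1` carries phenylsulfonyl in place of propyl on a nitrogen on an aromatic ring. Going by the values given here, no measured pair here shows what such a change does, so the direction is uncertain; a modest weakening is expected, with a 2.7-fold higher number from compound 2 to compound 3 (0.43 log units; beyond the scatter) as the estimated step. For compound 3 in this assay the expected value is 100 nM, with a range from 25 nM to 600 nM.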

Compound 3, half-maximal inhibitory concentration: 166 nM
Beside the measured number, compound 3's estimate is 1.7-fold (0.22 log units) below it; the measured number falls inside the stated range.
By their numbers in this assay, from the lowest: compounds 2 and 1 (each within the scatter of the next); then compound 3.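

On the nitrogen on an aromatic ring, phenylsulfonyl in place of propyl gives a 4.5-fold higher number from compound 2 to compound 3 (0.65 log units; beyond the scatter) in this assay, so this position does respond to what it carries. The step is a weakening, yet compound 3 still has a measured inhibition with a larger group there, one that brings in a six-membered aromatic ring. Nothing at hand says why the number rises. Going by these compounds, the phenyl ring and the sulfonyl part enter together, so which of them carries the step stays open. On these data alone, whether a methylsulfonyl or acetyl group on this nitrogen would stay closer to compound 2 is also open.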